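Chloro Enters the Pyrazole-Bearing Core of Compound 1

The compounds below may be only part of what the source reports. "The series", "measured", "known", "first", "only" and "open" are said of these compounds alone.

Of the compounds shown here, three built on a shared core have been measured in a functional assay on CHO cells for agonist activity at Alpha-1A adrenergic receptor (Homo sapiens), read by FLIPR and calcium flux; on this read-out higher numbers stand for larger maximal responses and lower numbers for smaller maximal responses. Compound 1 `c1cc(-c2ccn[nH]2)c2c(c1)C(c1ncc[nH]1)CC2` gives 83% in this assay. Compound 2 `CS(=O)(=O)Nc1cccc2c1CCC2c1ncc[nH]1` gives 87%, and compound 3 `Cc1oncc1-c1cccc2c1CCC2c1ncc[nH]1` gives 63%. On these three numbers compound 1 stands second highest: its nearest neighbour is compound 2, with a number 4 percentage points higher from compound 1 to compound 2 (within the scatter), and the furthest is compound 3, with a number 20 percentage points lower from compound 1 to compound 3 (beyond the scatter). The remaining step, a number 24 percentage points lower from compound 2 to compound 3 (beyond the scatter), is of similar size to that second one.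

Compound 4 `Clc1ccc2c(c1-c1ccn[nH]1)CCC2c1ncc[nH]1` has not yet been measured in this assay. It differs from compound 1 in a single place: chloro in place of hydrogen on an aromatic carbon. None of the three measured steps speaks directly to this change, since each of them replaces the group on the aromatic carbon that compound 1 carries as 1H-pyrazol-5-yl, whereas compound 4 keeps that group and adds a chloro elsewhere on the same ring. Among the measured compounds shown here, with no measured counterpart, the value of compound 1 is the only anchor. The step from compound 1 to compound 4 is therefore expected to be small, a number 3 percentage points lower from compound 1 to compound 4 (within the scatter), most likely within the scatter. Compound 4 is estimated to give 80% in this assay, between 62% and 95%.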

Compound 4, largest response reached (Emax), in percent of the reference or control that the assay uses: 40%
Estimate against measurement, compound 4: 40 percentage points above, outside the stated range (below it).
By their numbers in this assay, from the lowest: compound 4; then compound 3; then compounds 1 and 2 (each within the scatter of the next).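

The single added chloro, on an aromatic carbon ortho to a 1H-pyrazol-5-yl group, gives a number 43 percentage points lower from compound 1 to compound 4 (beyond the scatter) in this assay, so this position is far from indifferent to substitution even though it carries only hydrogen in the three earlier compounds. The earlier steps shown here all exchanged the group on the neighbouring aromatic carbon and ranged from within the scatter to modest, whereas this change keeps the 1H-pyrazol-5-yl group and adds one heavy atom, yet produces a step printed as large. Nothing available accounts for the size of this step, so the finding stands as an observation without a stated cause.

The compounds shown leave open whether the fall in maximal response belongs to chloro itself or would also follow from fluoro, methyl or methoxy at the same carbon. They also leave open whether chloro at this position would lower the response to a similar degree when the methanesulfonamido group of compound 2 or the 5-methyl-1,2-oxazol-4-yl group of compound 3 takes the place of the 1H-pyrazol-5-yl group.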